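Swapping the aryl tail for a tert-butyl group

This account rests on a few compounds, and the source may have more. Where it says the series, first, only, none or still open, it means among the compounds named here.

Three sulfonamides sharing one core have been tested in a functional assay on DLD-1 cells (Homo sapiens) for antiproliferative activity, read by CellTiter-Glo, with a stated time of 72 h; on this read-out lower numbers stand for stronger inhibition and higher numbers for weaker inhibition. Compound 1 `CC1CCN(C2CCN(S(=O)(=O)c3ccc(C#N)cc3)CC2)CC1` gives 2800 nM. Compound 2 `CCCCOc1ccc(S(=O)(=O)N2CCC(N3CCC(C)CC3)CC2)cc1` gives 2300 nM, and the step of a 1.2-fold lower number from compound 1 to compound 2 (0.09 log units; within the scatter) is within the scatter. Compound 3 `COc1ccc(-c2ccc(S(=O)(=O)N3CCC(N4CCC(C)CC4)CC3)cc2)cc1` gives 263 nM, the lowest of the three numbers; the steps of an 11-fold lower number from compound 1 to compound 3 (1.03 log units; beyond the scatter) and an 8.7-fold lower number from compound 2 to compound 3 (0.94 log units; beyond the scatter) both lie beyond the scatter, so compound 3 stands clearly apart from compounds 1 and 2.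

Compound 4 `CC1CCN(C2CCN(S(=O)(=O)c3ccc(C(C)(C)C)cc3)CC2)CC1` differs from compound 3 in one place: tert-butyl in place of 4-methoxyphenyl on an aromatic carbon. The two measured steps that bear on this are those ending in compound 3, an 11-fold lower number from compound 1 to compound 3 (1.03 log units; beyond the scatter) and an 8.7-fold lower number from compound 2 to compound 3 (0.94 log units; beyond the scatter), where a small group without a ring was replaced by 4-methoxyphenyl and the number fell sharply. Going the other way, from 4-methoxyphenyl to tert-butyl, a rise of similar size is therefore expected in this assay, though tert-butyl is neither cyano nor butoxy, so the rise may fall short of a full return. The expected step is a 5.7-fold higher number from compound 3 to compound 4 (0.76 log units; beyond the scatter). Compound 4 is estimated to give 1500 nM, with a range from 450 nM to 5000 nM.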

Compound 4, half-maximal inhibitory concentration: > 5000 nM
Compound 4 was reported as a limit; the forecaster's own chance of this, stated with the estimate: 5%; middle value at least 3.3-fold (0.52 log units) away from the limit.
By their numbers in this assay, from the lowest: compound 3; then compounds 2 and 1 (each within the scatter of the next). At a limit, above all of these: compound 4.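

Compound 4 is reported only as a limit, not as a number: the limit of > 5000 nM in this assay, at which 1 of the 4 values shown sits. Even so, the step of an at least 19-fold higher number from compound 3 to compound 4 (1.27 log units; beyond the scatter) shows that on this aromatic carbon the low number of compound 3 does not survive the exchange of 4-methoxyphenyl for tert-butyl, so among these four compounds only the one with a ring in this place reaches a low number. Tert-butyl also does worse here than butoxy, with an at least 2.1-fold higher number from compound 2 to compound 4 (0.33 log units; beyond the scatter), whereas the step of an at least 1.7-fold higher number from compound 1 to compound 4 (0.25 log units; that floor lies within the scatter) gives no firm order between tert-butyl and cyano.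

As far as these compounds go, whether the low number of compound 3 comes from the added ring itself or from its methoxy group stays open, and a plain phenyl or a pyridine ring in this place would help to separate the two. Also open, from the compounds shown here alone, is how an amine or a carboxylic acid on that ring would fare.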